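The compounds below may be only part of what the source reports. "The series", "measured", "known", "first", "only" and "open" are said of these compounds alone.

Working notes on the series. In a functional assay on MCF7 cells (Homo sapiens) for inhibition, read by sulforhodamine B assay, with a stated time of 48 h, tested at 100 uM (a higher number here means a weaker effect of the compound at the concentration tested, a lower number a stronger effect), compound 1 `COc1cc(Cl)cc(-c2nn(-c3cccc(NC(=O)c4cccc(C(F)(F)F)c4)c3)cc2-c2ccncc2)c1` gives 38%, while compound 2 `O=C(Nc1cccc(-n2cc(-c3ccncc3)c(-c3cc(O)cc(Cl)c3)n2)c1)Nc1ccc(Cl)c(Cl)c1` gives -2%. Compound 2 thus stands lowest of the two numbers seen so far, and compound 1 lies higher, a gap beyond the usual scatter of this assay. For the measured compounds named here, the two differ in more than one place, so no single-point step connects them.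

Compound 3 `COc1cc(Cl)cc(-c2nn(-c3cccc(NC(=O)Nc4ccc(Cl)c(Cl)c4)c3)cc2-c2ccncc2)c1` has not been measured. It differs from compound 2 by methyl in place of hydrogen on an oxygen on an aromatic ring, the difference reading hydroxy to methoxy, or 3-chloro-5-hydroxyphenyl to 3-chloro-5-methoxyphenyl, one bond further out. Going by the values given here, no measured pair isolates this change, so the expected size of the step rests only on the general character of a one-carbon change. A modest step upward is expected from compound 2 to compound 3, a number 17 percentage points higher from compound 2 to compound 3 (beyond the scatter), in this assay. The estimate for compound 3 is 15%, with a range from -10% to 45%.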

Compound 3, a percentage reported as activity, at one concentration (the size of the read-out at that concentration, not a potency): -13%
Estimate against measurement, compound 3: 28 percentage points above, and the stated range ends above it.
By their numbers in this assay, from the lowest: compound 3; then compound 2; then compound 1.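

In this assay, methyl in place of hydrogen on an oxygen on an aromatic ring gives a number 11 percentage points lower from compound 2 to compound 3 (beyond the scatter), so at this position the hydrogen of the hydroxy group is not required for the effect at the concentration tested, and methoxy gives the stronger read-out. For the compounds shown here, with methoxy held constant, (3,4-dichlorophenyl)amino in place of 3-(trifluoromethyl)phenyl on a carbonyl carbon gives a number 51 percentage points lower from compound 1 to compound 3 (beyond the scatter), which isolates that change in a single place for the first time. No measurement available here accounts for either step.

Going by these compounds, whether an ethoxy group, an amine or a carboxylic acid at this position would extend or reverse the methoxy step remains open. These read-outs come from one concentration, so neither step gives a difference in potency.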